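This account rests on a few compounds, and the source may have more. Where it says the series, first, only, none or still open, it means among the compounds named here.

Among the measured compounds shown here, in an ADME assay on microsomes from liver (Homo sapiens) for metabolic stability, read by LC-MS, using NADPH, with a stated time of 10 min, tested at 10 uM (a higher number here means that the compound lasts longer, a lower number that the compound disappears faster), compound 1 `Nc1ncnc2c1c(Oc1cc(C(F)(F)F)ccn1)nn2CC1CC1` gives 1.87 h as the only exact number available. Compound 2 `N#Cc1ccnc(Oc2nn([C@H]3C[C@H](O)C3)c3ncnc(N)c23)c1` reads > 2.41 h and that is a limit of the assay, not a number. Compound 3 `CO[C@H]1CC[C@H](n2nc(Oc3cc(C(F)(F)F)ccn3)c3c(N)ncnc32)CC1` keeps the core of compound 1 but carries 4-methoxycyclohexyl in place of cyclopropylmethyl on an aromatic nitrogen. For the measured compounds named here, no measured step bears on this change, so only a small fall in half-life, within the scatter, is expected in this assay (a 1.4-fold lower number from compound 1 to compound 3 (0.16 log units; within the scatter)). For compound 3 the estimated half-life is 1.3 h with an expected range of (0.6 h to 2.6 h).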

Compound 3, half-life: > 2.41 h
Compound 3: only a limit was reported (the forecaster's own chance of this, stated with the estimate: 15%); at least 1.8-fold (0.26 log units) between middle value and limit.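

On the aromatic nitrogen, the larger 4-methoxycyclohexyl in place of cyclopropylmethyl brings no visible loss of half-life in this assay, with an at least 1.2-fold higher number from compound 1 to compound 3 (0.11 log units; that floor lies within the scatter). Compound 3 reads > 2.41 h, which is a limit of the assay and not a number. The true size of this step therefore stays unknown: the limit of > 2.41 h in this assay, at which 2 of the 3 values shown sit.

The compounds shown do not separate the part played by the methoxy group from that of the cyclohexyl ring. As far as these compounds go, how an amine or a hydroxyl group on that ring, or an open alkyl chain at this nitrogen, would fare remains open.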